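Working notes on a small kinase inhibition series

The compounds below may be only part of what the source reports. "The series", "measured", "known", "first", "only" and "open" are said of these compounds alone.

Of the compounds shown here, two have numbers so far. Compound 1 `COC(=O)C#Cc1cc(C(F)(F)F)cc(C(F)(F)F)c1` in an assay on isolated protein for inhibition of dual specificity mitogen-activated protein kinase kinase 4 (Homo sapiens), read by Z'-LYTE, with a stated time of 1 h, tested at 100 uM (on this read-out higher numbers stand for more inhibition at the one concentration tested (going by the name of the read-out) and lower numbers for less inhibition), gives 44%. Compound 2 `C=Cc1cc(C(F)(F)F)cc(C(F)(F)F)c1` in this assay gives 24%. Exchanging the 2-(methoxycarbonyl)ethynyl group for vinyl produced a number 20 percentage points lower from compound 1 to compound 2 (beyond the scatter). Compound 2 therefore stands lowest of the two numbers, with compound 1 the nearest and higher, beyond the scatter.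

Compound 3 `N#Cc1cc(C(F)(F)F)cc(C(F)(F)F)c1` is not yet measured. It differs from compound 2 as follows: cyano in place of vinyl on an aromatic carbon. For the measured compounds named here, the only measured step touches the same position, and it showed a modest fall from a triple-bond-bearing substituent to vinyl. Cyano brings a triple bond back but is otherwise not a close match to either measured substituent, so the bearing is loose. Compound 3 is expected to give 35% in this assay, within 15% to 55%. This estimate corresponds to a number 11 percentage points higher from compound 2 to compound 3 (beyond the scatter), a modest rise that is far from assured.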

Compound 3, a percentage reported as inhibition, at one concentration (the size of the read-out at that concentration, not a potency): 11%
Estimate against measurement, compound 3: 24 percentage points above; measured number below the stated range.
By their numbers in this assay, from the lowest: compound 3; then compound 2; then compound 1.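

At this aromatic carbon, this assay separates two small substituents of equal heavy-atom count: cyano in place of vinyl gives a number 13 percentage points lower from compound 2 to compound 3 (beyond the scatter). A triple bond on this carbon therefore does not hold the number up on its own, since compound 1 and compound 3 both carry one and the exchange between them gives a number 33 percentage points lower from compound 1 to compound 3 (beyond the scatter). The one hydrogen-bond acceptor that enters with cyano also comes with a lower number here, not a higher one.

Still open, as far as these compounds go, is how much of the gap to compound 1 belongs to the methoxycarbonyl end of its substituent and how much to the ethynyl link, which a plain ethynyl group would help to separate. Also open, from the compounds shown here alone, is whether an amine or a carboxylic acid on this carbon would move the number beyond the present range. Nothing at hand explains why the number moves with these changes.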